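The source may hold more compounds than are shown below. What is called first, only, known or untested is meant among the compounds shown, and "the series" means these compounds.

Compound 3 `COCCCNc1nc(C)nc2c1nnn2-c1ccc(C(C)C)cc1Br` gives 291 nM in an in vitro assay on 293-EBNA cells for binding affinity to corticotropin-releasing factor receptor 1 (Homo sapiens) (a higher number here means a weaker inhibitor, a lower number a stronger inhibitor), the highest of the three numbers: against compound 2 `COCC(C)(C)Nc1nc(C)nc2c1nnn2-c1ccc(C(C)C)cc1Br` with 195 nM the gap is a 1.5-fold higher number from compound 2 to compound 3 (0.17 log units; within the scatter), and against compound 1 `CCN(CC)c1nc(C)nc2c1nnn2-c1ccc(C(C)C)cc1Br` with 25.3 nM it is a 12-fold higher number from compound 1 to compound 3 (1.06 log units; beyond the scatter). Compound 4 `CCCCC(CC)Nc1nc(C)nc2c1nnn2-c1ccc(C(C)C)cc1Br` differs from compound 3 by 1-ethylpentyl in place of 3-methoxypropyl on a nitrogen on an aromatic ring. Among the measured compounds shown here, no measured step swaps a group on this nitrogen for one without an oxygen; the one step at this nitrogen, a 1.5-fold higher number from compound 2 to compound 3 (0.17 log units; within the scatter), lay within the scatter, while a 7.7-fold higher number from compound 1 to compound 2 (0.89 log units; beyond the scatter) shows how far the numbers move when the amine substituent changes. A moderate step downward, beyond the scatter, is therefore expected, a 9.7-fold lower number from compound 3 to compound 4 (0.99 log units; beyond the scatter). Compound 4 is estimated at 30 nM in this assay, between 8 nM and 120 nM.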

Compound 4, inhibition constant: 3.1 nM
Estimate against measurement, compound 4: 9.7-fold (0.99 log units) above, outside the stated range (below it).
By their numbers in this assay, from the lowest: compound 4; then compound 1; then compounds 2 and 3 (each within the scatter of the next).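

With 1-ethylpentyl on this nitrogen, the number falls sharply, with a 94-fold lower number from compound 3 to compound 4 (1.97 log units; beyond the scatter) and a 63-fold lower number from compound 2 to compound 4 (1.80 log units; beyond the scatter), whereas the two oxygen-bearing groups stayed within the scatter of each other. Replacing diethylamino therefore need not raise the number, as an 8.2-fold lower number from compound 1 to compound 4 (0.91 log units; beyond the scatter) shows, and compound 4 stands lowest of the four. This change removes the oxygen and alters the chain together, so the two cannot be separated here.

Nothing available explains the drop. From the compounds shown here alone, whether a pentyl chain or a cyclopentyl group on this nitrogen would also lower the number remains open.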